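The source may hold more compounds than are shown below. What is called first, only, known or untested is meant among the compounds shown, and "the series" means these compounds.

For the measured compounds named here, compound 2 `Cc1ccc(S(=O)(=O)NC(=O)Nc2ccccc2C(=O)/C=C/c2cccc(F)c2)cc1` gives 4.13 ug/mL in an ADME assay on the whole organism for cytotoxicity, with Artemia salina as the target, with a stated time of 24 h (on this read-out lower numbers stand for an effect already at smaller amounts and higher numbers for an effect only at larger amounts of compound), the lowest of the two numbers measured so far. Its nearest neighbour is compound 1 `CCc1cc(/C=C/C(=O)c2ccccc2NC(=O)NS(=O)(=O)c2ccc(C)cc2)cc(OC)c1OC`, which in this assay gives 19.2 ug/mL; putting 3-fluorophenyl in place of 3-ethyl-4,5-dimethoxyphenyl on a double-bonded chain carbon produced a 4.6-fold lower number from compound 1 to compound 2 (0.67 log units; beyond the scatter). The next compound, compound 3 `Cc1ccc(S(=O)(=O)NC(=O)Nc2ccccc2C(=O)/C=C/c2cccnc2)cc1`, differs from compound 2 at that same place: pyridin-3-yl in place of 3-fluorophenyl on a double-bonded chain carbon bound to a double-bonded chain carbon. Going by the values given here, only the one measured step bears on this position, and it shows that the ring there can shift the read-out by a modest amount; nothing measured shows how pyridin-3-yl compares with 3-fluorophenyl. The chemist therefore expects a small step, a 1.7-fold higher number from compound 2 to compound 3 (0.23 log units; within the scatter), more likely toward a somewhat higher number than a lower one, and estimates compound 3 at 7 ug/mL, with a range from 2.5 ug/mL to 20 ug/mL.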

Compound 3, concentration for half-maximal effect: 14.1 ug/mL
Compound 3: middle estimate off by 2.0-fold (0.30 log units), on the low side; measured number inside the range.
By their numbers in this assay, from the lowest: compound 2; then compounds 3 and 1 (each within the scatter of the next).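

In this assay, the ring on a double-bonded chain carbon bound to a double-bonded chain carbon shifts the read-out even when one ring with a single substituent gives way to a pyridine ring: pyridin-3-yl in place of 3-fluorophenyl gives a 3.4-fold higher number from compound 2 to compound 3 (0.53 log units; beyond the scatter). Pyridin-3-yl in place of 3-ethyl-4,5-dimethoxyphenyl gives a 1.4-fold lower number from compound 1 to compound 3 (0.13 log units; within the scatter), so these two rings cannot be told apart here, and of the three compounds only compound 2, with its 3-fluorophenyl, stands apart from the others. From the compounds shown here alone, what an unsubstituted phenyl, a 3-chlorophenyl or a pyridin-2-yl would give at this place stays open, and with it whether the low number of compound 2 follows the fluorine or the carbon-only ring. No measurement at hand offers an explanation for these differences.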